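Pyrazolyl for ethyl on the chlorophenyl amide

This account rests on a few compounds, and the source may have more. Where it says the series, first, only, none or still open, it means among the compounds named here.

Notes on the series measured in an ADME assay on the whole organism (strain Han-Wistar) for pharmacokinetics, with Rattus norvegicus as the target, read by LC-MS, at a dose of 2 mg/kg by the oral route; on this read-out lower numbers stand for lower exposure and higher numbers for higher exposure at the dose given. Compound 3 `CCc1ccc(Cl)c(C(=O)NC(=O)Nc2nc3ccc(S(=O)(=O)CCCN4CCN(C)CC4)cc3s2)c1` gives 1500 nM, the second highest number of the three measured; its nearest neighbour is compound 2 `CCOc1ccc(Cl)c(C(=O)NC(=O)Nc2nc3ccc(S(=O)(=O)CCCN4CCN(C)CC4)cc3s2)c1` with 4200 nM, and the furthest is compound 1 `CN1CCN(CCCS(=O)(=O)c2ccc3nc(NC(=O)NC(=O)c4cc(-n5cccn5)c(Cl)cc4Cl)sc3c2)CC1` with 30 nM. For the measured compounds named here, the one measured step at the same aromatic carbon, a 2.8-fold lower number from compound 2 to compound 3 (0.45 log units; beyond the scatter), is modest. Compound 4 `CN1CCN(CCCS(=O)(=O)c2ccc3nc(NC(=O)NC(=O)c4cc(-n5cccn5)ccc4Cl)sc3c2)CC1` carries the change (1H-pyrazol-1-yl in place of ethyl on an aromatic carbon). Going by the values given here, no measured step covers this exchange directly; the only bearing comes from compound 1, which also carries 1H-pyrazol-1-yl and, with 30 nM, stands far below compound 3, though compound 1 differs elsewhere on the same ring as well. The step from ethoxy to ethyl was small, so the entering ring, not a chain, is the main unknown. Compound 4 is therefore expected at 200 nM, within 40 nM to 1000 nM, leaning on compound 1. The step of a 7.5-fold lower number from compound 3 to compound 4 (0.88 log units; beyond the scatter) is thus expected downward, beyond the scatter.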

Compound 4, maximal plasma concentration: 1200 nM
For compound 4 the middle estimate is 6.0-fold (0.78 log units) below the measured one; measured number above the stated range.
By their numbers in this assay, from the lowest: compound 1; then compounds 4 and 3 (each within the scatter of the next); then compound 2.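

In this assay, 1H-pyrazol-1-yl in place of ethyl on this aromatic carbon, para to the chloro group, leaves the number within the scatter (a 1.3-fold lower number from compound 3 to compound 4 (0.10 log units; within the scatter)), so this position accepts the five-membered aromatic ring without a step that can be told from the scatter. Against ethoxy at the same carbon the ring gives a modest drop (a 3.5-fold lower number from compound 2 to compound 4 (0.54 log units; beyond the scatter)). The large change lies elsewhere on the ring, with hydrogen in place of chloro (a 40-fold higher number from compound 1 to compound 4 (1.60 log units; beyond the scatter)), so the pyrazolyl group alone does not bring the number down to the level of compound 1.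

As far as these compounds go, whether that chloro step holds with ethyl or ethoxy in place of the pyrazolyl group stays open, as does the reading for an amine or a carboxylic acid on this carbon. No measurement at hand accounts for any of these steps.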